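From Thiophen-3-yl to Pyrazin-2-yl on a Shared Core

The source may report more compounds than this note shows. Statements on the series, on what has been measured and on what is new or still open speak of the compounds shown alone.

Of the compounds shown here, three sharing one core have been tested in a physicochemical assay for solubility, in phosphate buffer, with a stated time of 18 h; on this read-out higher numbers stand for higher solubility and lower numbers for lower solubility. Compound 1 (`CC(C)(C)c1nc(C2CCCC2)c2c(N)c(C#N)c(N)nc2n1`), which carries cyclopentyl, gives < 1000 nM, a limit of the assay and not a number. Compound 2 (`CC(C)(C)c1nc(-c2nccs2)c2c(N)c(C#N)c(N)nc2n1`), which carries 1,3-thiazol-2-yl, gives < 1500 nM, also a limit. Going by the values given here, compound 3 (`CC(C)(C)c1nc(-c2ccsc2)c2c(N)c(C#N)c(N)nc2n1`), which carries thiophen-3-yl, gives 40000 nM, the only true number of the three and the highest reading among them. The measured steps leading to it are large: an at least 40-fold higher number from compound 1 to compound 3 (1.60 log units; beyond the scatter) and an at least 26-fold higher number from compound 2 to compound 3 (1.42 log units; beyond the scatter). The remaining step, a step that the two limits leave unreadable from compound 1 to compound 2, tells nothing about size.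

Compound 4 (`CC(C)(C)c1nc(-c2cnccn2)c2c(N)c(C#N)c(N)nc2n1`) has pyrazin-2-yl in place of thiophen-3-yl on an aromatic carbon. Among the compounds with values here, no measured step makes this exact exchange. The closest guide is compound 2, whose ring also holds nitrogen, and the step of an at least 26-fold higher number from compound 2 to compound 3 (1.42 log units; beyond the scatter) is therefore read in reverse, with caution. A clear fall in this assay is expected, though perhaps not all the way back to the limits seen so far. The expected change is an 8.0-fold lower number from compound 3 to compound 4 (0.90 log units; beyond the scatter). The estimate for compound 4 is 5000 nM, with an expected range from 1000 nM to 25000 nM.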

Compound 4, solubility: 86000 nM
Estimate against measurement, compound 4: 17-fold (1.24 log units) below; measured number above the stated range.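

In this assay, this position on an aromatic carbon, next to the ring nitrogen, now has two groups with true readings, and pyrazin-2-yl in place of thiophen-3-yl gives a 2.2-fold higher number from compound 3 to compound 4 (0.33 log units; beyond the scatter), a modest step that leaves compound 3 no longer the highest reading among those shown. Ring nitrogen alone therefore does not tie a compound to a low reading: 1,3-thiazol-2-yl and pyrazin-2-yl both hold it, yet the exchange between them gives an at least 57-fold higher number from compound 2 to compound 4 (1.75 log units; beyond the scatter), a step whose true size stays unknown, as one end of it is a limit of the assay. Pyrazin-2-yl in place of cyclopentyl gives an at least 86-fold higher number from compound 1 to compound 4 (1.93 log units; beyond the scatter), and this step too has a limit of the assay at one end, so its true size is also unknown.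

No measurement shown bears on what lies behind these differences. As far as these compounds go, it remains open whether pyridin-2-yl, or a pyrazin-2-yl ring carrying an amine or a carboxylic acid, would read nearer compound 3 or compound 4 in this assay.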